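This account rests on a few compounds, and the source may have more. Where it says the series, first, only, none or still open, it means among the compounds named here.

Compound 1 `COc1ccc(C2=C(c3cc(OC)c(OC)c(OC)c3)C(=O)CC2O)cc1O`: > 100 ug/mL
Compound 2 `COc1cc(C2=C(c3cc(C)c(OC)c(C)c3)C(O[SiH2]C(C)(C)C)CC2=O)cc(OC)c1OC`: "not determined" (no result reported)

In an ADME assay on MIA PaCa-2 cells (Homo sapiens) for cytotoxicity, read by MTT assay, with a stated time of 72 h (a higher number here means a weaker inhibitor, a lower number a stronger inhibitor), compound 1 gives > 100 ug/mL; this is a limit of the assay, not a number. Compound 2 has no result in this assay, where it gives "not determined" (no result reported), so no number stands for it. Compound 3 `COc1ccc(C2=C(c3cc(OC)c(OC)c(OC)c3)C(=O)CC2O[SiH2]C(C)(C)C)cc1O` is not yet measured. It differs from compound 2 by 3-hydroxy-4-methoxyphenyl in place of 4-methoxy-3,5-dimethylphenyl on a double-bonded ring carbon. Within the data shown here, with no measured step between two compounds to go by, no size or direction of change in this assay can be read from these compounds. Compound 3 is expected to give about 100 ug/mL in this assay, within 40 ug/mL to 250 ug/mL, and a limit rather than a number is expected to be quite possible.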

Compound 3, half-maximal inhibitory concentration: 55 ug/mL
Compound 3: middle estimate off by 1.8-fold (0.26 log units), on the high side, and the stated range covers the measured number.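

Among these compounds, this is the first readable step at this position: a silicon-bearing group in place of the hydrogen, on an oxygen on a saturated carbon, gives an at least 1.8-fold lower number from compound 1 to compound 3 (0.25 log units; that floor lies within the scatter) in this assay. Since the floor of that step does not clear the scatter, it does not yet show a real change. Its true size stays unknown because compound 1 stands at a limit: the limit of > 100 ug/mL in this assay, at which 1 of the 3 values shown sits.

The change between compound 2 and compound 3 cannot be read, as compound 2 has no number. From the compounds shown here alone, whether an amine or a longer carbon chain at this oxygen would lower the number remains open.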